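This account rests on a few compounds, and the source may have more. Where it says the series, first, only, none or still open, it means among the compounds named here.

Working notes on the series.

Three compounds sharing one core have numbers in an assay on CHO cells for displacement of a labelled ligand from adenosine receptor A3 (Homo sapiens), read by scintillation counting, with a stated time of 45 min, tested at 1 uM, in the presence of a further agent that is not named here; on this read-out lower numbers stand for less inhibition and higher numbers for more inhibition at the one concentration tested (going by the name of the read-out). Compound 1 `CCCn1c(=O)[nH]c2nc(-c3ccc(S(=O)(=O)N4CCN(c5ccc(Cl)cc5F)CC4)cc3)[nH]c2c1=O` gives 14% in this assay. Compound 2 `CCCn1c(=O)[nH]c2nc(-c3ccc(S(=O)(=O)N4CCN(Cc5cccc(Br)c5)CC4)cc3)[nH]c2c1=O` gives 23% in this assay. Compound 3 `CCCn1c(=O)[nH]c2nc(-c3ccc(S(=O)(=O)N4CCN(C(C)c5ccccc5)CC4)cc3)[nH]c2c1=O` gives 0% in this assay, the lowest of the three numbers; its nearest neighbour is compound 1 and its furthest compound 2, and both gaps lie beyond the scatter.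

The measured steps: a number 9 percentage points higher from compound 1 to compound 2 (within the scatter) sits within the scatter; a number 14 percentage points lower from compound 1 to compound 3 (beyond the scatter) is beyond it; a number 23 percentage points lower from compound 2 to compound 3 (beyond the scatter) is beyond it as well and is the largest move seen.

Compound 4 `CCCn1c(=O)[nH]c2nc(-c3ccc(S(=O)(=O)N4CCN(Cc5ccc(Br)c(F)c5)CC4)cc3)[nH]c2c1=O` is the next entry. Its change from compound 3 is 4-bromo-3-fluorobenzyl in place of 1-phenylethyl on an amine nitrogen in a ring. Among the measured compounds shown here, the step that bears most directly on it is the one from compound 2 to compound 3, since compound 4 returns a benzyl group with ring halogens to the ring nitrogen, and that step ran downward by a modest amount; the step from compound 1 to compound 3 points the same way. For the measured compounds named here, a rise beyond the scatter is therefore expected, of roughly the size of those steps, though the exact halogen pattern of compound 4 has no measured counterpart here.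

Compound 4 is expected to give about 20% in this assay, within 5% to 38%. The expected step is a number 20 percentage points higher from compound 3 to compound 4 (beyond the scatter).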

Compound 4, a percentage reported as inhibition, at one concentration (the size of the read-out at that concentration, not a potency): 27%
Compound 4: the middle estimate sits 7 percentage points below what was measured, and the stated range covers the measured number.
By their numbers in this assay, from the lowest: compound 3; then compounds 1, 2 and 4 (each within the scatter of the next, the first and the last beyond it).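

In this assay, 4-bromo-3-fluorobenzyl in place of 1-phenylethyl on the ring amine nitrogen gives a number 27 percentage points higher from compound 3 to compound 4 (beyond the scatter), so compound 3 now sits beyond the scatter from a second halogen-bearing benzyl compound and not only from compound 2. The halogen pattern on the benzyl ring does not separate the two benzyl compounds, with 4-bromo-3-fluorophenyl in place of 3-bromophenyl on the saturated chain carbon giving a number 4 percentage points higher from compound 2 to compound 4 (within the scatter), while the comparison with the directly attached aryl group gives a number 13 percentage points higher from compound 1 to compound 4 (beyond the scatter), a separation that compound 2 does not share, as a number 9 percentage points higher from compound 1 to compound 2 (within the scatter) shows. Nothing available here accounts for these differences.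

On these data alone, it remains open whether the low number of compound 3 goes with the extra methyl of 1-phenylethyl or with the absence of ring halogens, and an unsubstituted benzyl group on the same nitrogen would separate the two. Among the compounds shown here, also open is how a benzyl ring carrying a methoxy group or a nitrile in place of the halogens would compare, and these single-concentration numbers give no potency for any compound.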